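This account rests on a few compounds, and the source may have more. Where it says the series, first, only, none or still open, it means among the compounds named here.

Measured in a functional assay on HeLa cells (Homo sapiens) for inhibition, read by MTT assay, with a stated time of 72 h; a higher number here means a weaker inhibitor, a lower number a stronger inhibitor:
compound 1 `O=[N+]([O-])c1ccc(Nc2nnc(-c3c[nH]c4ccccc34)o2)cc1`: 1760 nM
compound 2 `Clc1ccc(Nc2nnc(-c3c[nH]c4ccccc34)o2)cc1`: 3800 nM
compound 3 `COc1ccc(Nc2nnc(-c3c[nH]c4ccccc34)o2)cc1`: 5820 nM

In this assay, compound 2 at 3800 nM sits at the weak end of this small set, together with compound 3 at 5820 nM. The gap there is a 1.5-fold higher number from compound 2 to compound 3 (0.19 log units; within the scatter). Compound 1 is the strongest of the three, and the gaps at that end are a 2.2-fold higher number from compound 1 to compound 2 (0.33 log units; beyond the scatter) and a 3.3-fold higher number from compound 1 to compound 3 (0.52 log units; beyond the scatter).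

Compound 4 `c1ccc(CNc2nnc(-c3c[nH]c4ccccc34)o2)cc1` is not yet measured. Its change is benzyl in place of 4-chlorophenyl on a nitrogen on an aromatic ring.

Going by the values given here, no measured step covers a change at that nitrogen. All three steps swap one group on an aromatic carbon, so they bear on this change only indirectly, as a guide to how far the numbers in this set move. The largest of them, a 3.3-fold higher number from compound 1 to compound 3 (0.52 log units; beyond the scatter), is only modest. A step of about that size in this assay is therefore the outer expectation, with no firm direction, and a step beyond the scatter is not expected. The expected step is a 1.2-fold higher number from compound 2 to compound 4 (0.07 log units; within the scatter). For compound 4 the estimated value is 4500 nM, with an expected range from 1500 nM to 14000 nM.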

Compound 4, half-maximal inhibitory concentration: 7810 nM
Compound 4: the middle estimate sits 1.7-fold (0.24 log units) below what was measured; the measured number falls inside the stated range.
By their numbers in this assay, from the lowest: compound 1; then compounds 2, 3 and 4 (each within the scatter of the next, the first and the last beyond it).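

Going by these compounds alone, at the nitrogen on an aromatic ring, a place the earlier steps did not touch, benzyl in place of 4-chlorophenyl gives a 2.1-fold higher number from compound 2 to compound 4 (0.31 log units; beyond the scatter) in this assay and so shows that the number responds to a change at this position. Both groups carry 7 heavy atoms and one six-membered aromatic ring of carbon only, so this step arises with those counts unchanged, and the group leaving differs from the one entering in its chlorine and its carbon count. Within the data shown here, no measurement here accounts for the step, and the single pair cannot separate the loss of the chlorine from the change in how the ring is joined to that nitrogen.

The compounds shown leave open how a plain phenyl, a 4-chlorobenzyl or a longer chain such as 2-phenylethyl would read at this nitrogen, which would help to separate those two changes. Also open, as far as these compounds go, are an amine or a carboxylic acid on the benzyl ring, and whether the steps among nitro, chloro and methoxy on the aromatic carbon carry over to the benzyl series.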